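The compounds below may be only part of what the source reports. "The series", "measured", "known", "first", "only" and "open" are said of these compounds alone.

Measured so far in an in vitro ADME assay on microsomes from liver (Rattus norvegicus) for metabolic stability; a lower number here means that the compound disappears faster, a higher number that the compound lasts longer
- compound 1 `Cc1nc2ccc(-c3ccccc3Cl)c(CN)c2n1C` gives 0.117 h
- compound 2 `CCn1cnc2ccc(-c3ccc(Cl)cc3Cl)c(CN)c21` gives 0.7 h

Compound 1 at 0.117 h holds the lower of these two numbers, and compound 2 at 0.7 h lies above it by more than the scatter. Compound 3 `COCc1nc2ccc(-c3ccccc3Cl)c(CN)c2n1C` departs from compound 1 by one change methoxy in place of hydrogen on a saturated chain carbon bound to an aromatic carbon in which methoxy stands in place of hydrogen on a saturated chain carbon bound to an aromatic carbon, the same difference reading as methyl to methoxymethyl. Within the data shown here, no measured pair shows this change, and compound 2 differs from compound 1 in more than one place. In this assay the estimated step of a 1.2-fold lower number from compound 1 to compound 3 (0.07 log units; within the scatter) is expected to stay within the scatter, with no direction favoured. Compound 3 is expected at 0.1 h with an estimated range from 0.045 h to 0.23 h for its half-life.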

Compound 3, half-life: 0.183 h
Estimate against measurement, compound 3: 1.8-fold (0.26 log units) below; the range from low to high includes it.
By their numbers in this assay, from the lowest: compounds 1 and 3 (each within the scatter of the next); then compound 2.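

In this assay the saturated chain carbon bound to an aromatic carbon now has its first reading: methoxy in place of hydrogen, the same difference as methyl to methoxymethyl, comes out as a 1.6-fold higher number from compound 1 to compound 3 (0.19 log units; within the scatter) and does not separate the two compounds. On the core of compound 1 this position therefore takes the added methoxy, with its 2 heavy atoms and 1 hydrogen-bond acceptor, without a difference in half-life that stands clear of repeat measurements. Nothing measured here speaks to why the two compounds read alike.

Going by these compounds, whether another group at this position, such as an amine, a carboxylic acid or a longer chain, would give a step beyond the scatter remains open. Compound 2 differs from compound 1 in more than one place and gives no reading of this position.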